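The source may hold more compounds than are shown below. What is called first, only, known or untested is meant among the compounds shown, and "the series" means these compounds.

Measured compounds:
compound 1 `O=C(CCC1=CCN(CCCc2ccc(Cl)cc2)C1=O)NO` — 5100 nM
compound 2 `O=C(CCC1=CCN(Cc2ccc(Br)cc2F)C1=O)NO` — 4720 nM

In a functional assay on HCT-15 cells (Homo sapiens) for inhibition, read by sulforhodamine B assay (a higher number here means a weaker inhibitor of growth, a lower number a stronger inhibitor of growth), compound 1 gives 5100 nM. Compound 2 gives 4720 nM in this assay. Compound 1 holds the higher of the two numbers shown, but the gap to compound 2 lies within the usual scatter of repeated measurements, so the two compounds cannot be ranked against each other on these data, and no single-point step between measured compounds is available for the series.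

Compound 3 `Cc1ccc(CCCN2CC=C(CCC(=O)NO)C2=O)cc1` has not yet been measured in this assay. Against compound 1 the change is methyl in place of chloro on an aromatic carbon. One heavy atom leaves and one heavy atom enters, with no change in ring count, in hydrogen-bond donors or acceptors, or in net charge. For the measured compounds named here, no measured pair bears on this kind of exchange, so there is nothing to set a direction from.

The expectation for compound 3 is therefore a step from compound 1 of a 1.1-fold higher number from compound 1 to compound 3 (0.03 log units; within the scatter), not expected to exceed the scatter in either direction. Compound 3 is estimated at 5500 nM in this assay, with a range from 2500 nM to 12000 nM.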

Compound 3, concentration for 50% growth inhibition: 5100 nM
Compound 3: middle estimate off by 1.1-fold (0.03 log units), on the high side; measured number inside the range.
By their numbers in this assay, from the lowest: compounds 2, 1 and 3 (each within the scatter of the next).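

In this assay, for the compounds shown here, methyl in place of chloro on an aromatic carbon, para to a large group, gives no change at the digits printed from compound 1 to compound 3 (within the scatter), and this is the first single-place step. At this position, therefore, 4-chlorophenyl and 4-methylphenyl cannot be told apart by this read-out, a finding that applies to this one exchange on the core of compound 1 and sets no trend for other substituents. No measurement available here accounts for the two groups reading alike.

The compounds shown leave open whether a group of a different kind at this same position, such as an amine, a carboxylic acid or a methoxy group, would also stay within the scatter of compound 1, or whether the level reading holds only for the chloro and methyl pair. Also open, from the compounds shown here alone, is whether the exchange of chloro for methyl would read the same with a longer chain in place of the one carrying the aromatic ring in compound 1.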